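Replacing the Side Arm on a Shared Core

The compounds below may be only part of what the source reports. "The series", "measured", "known", "first", "only" and "open" are said of these compounds alone.

Compound 1, `CN1CCN(c2ccc(C3=NN(C(=O)CCCl)C(c4ccc(N(C)C)cc4)C3)cc2)CC1`: 2.4%
Compound 2, `COC(=O)CC(=O)N1N=C(c2ccc(N3CCN(C)CC3)cc2)CC1c1ccc(N(C)C)cc1`: -0.4%
Compound 3, `CN1CCN(c2ccc(C3=NN(C(=O)/C=C/c4ccccc4)C(c4ccc(N(C)C)cc4)C3)cc2)CC1`: 35.9%

In a functional assay on MDA-MB-231 cells (Homo sapiens) for inhibition, read by sulforhodamine B assay, tested at 10 uM (on this read-out higher numbers stand for more inhibition at the one concentration tested (going by the name of the read-out) and lower numbers for less inhibition), compound 3 stands highest of the three numbers, lying a number 33.5 percentage points higher from compound 1 to compound 3 (beyond the scatter) and a number 36.3 percentage points higher from compound 2 to compound 3 (beyond the scatter). Compound 4, `CN1CCN(c2ccc(C3=NN(S(=O)(=O)c4ccc(F)cc4)C(c4ccc(N(C)C)cc4)C3)cc2)CC1`, differs from compound 3 in one place: (4-fluorophenyl)sulfonyl in place of (2-phenylethenyl)carbonyl on an amine nitrogen in a ring. Going by the values given here, no measured step puts a sulfonyl group on that ring nitrogen. The two large steps both concern the 2-phenylethenyl group that now leaves, while a number 2.8 percentage points lower from compound 1 to compound 2 (within the scatter) shows that a change confined to the chain beyond the carbonyl carbon made little difference. Since the group that accompanied both large rises is removed, a fall is expected, a number 23.9 percentage points lower from compound 3 to compound 4 (beyond the scatter). Compound 4 is therefore estimated at 12%, within a range from -5% to 30%.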

Compound 4, a percentage reported as inhibition, at one concentration (the size of the read-out at that concentration, not a potency): 15.7%
Compound 4: middle estimate off by 3.7 percentage points, on the low side, within the range that was stated.
By their numbers in this assay, from the lowest: compounds 2 and 1 (each within the scatter of the next); then compound 4; then compound 3.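

With (4-fluorophenyl)sulfonyl on the ring nitrogen, the side arm need not be joined through a carbonyl for inhibition to appear: there is a number 13.3 percentage points higher from compound 1 to compound 4 (beyond the scatter) and a number 16.1 percentage points higher from compound 2 to compound 4 (beyond the scatter). This arm still does not match (2-phenylethenyl)carbonyl, with a number 20.2 percentage points lower from compound 3 to compound 4 (beyond the scatter). Both arms carry one six-membered aromatic ring of carbon only, so that ring alone does not settle the number.

Nothing available explains these differences. Going by these compounds, whether the sulfonyl link or the fluorine matters stays open, and a plain phenylsulfonyl group without the fluorine would help separate the two.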